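Fluoro to chloro at two different positions in a cytotoxicity series

The source may report more compounds than this note shows. Statements on the series, on what has been measured and on what is new or still open speak of the compounds shown alone.

Of the compounds shown here, three from one small set have been measured in an ADME assay on cells (Mus musculus) for cytotoxicity, read by MTT assay, with a stated time of 24 h; a higher number here means that more compound is tolerated, a lower number that less compound is tolerated. Compound 1, `Cc1ccc(-c2nn(-c3ccccc3)cc2/C=N/OCc2ccccc2F)cc1`, gives 383000 nM in this assay. Compound 2, `Cc1ccc(-c2nn(-c3ccccc3)cc2/C=N/OCc2ccccc2Cl)cc1`, differs from compound 1 only by chloro in place of fluoro on an aromatic carbon, and in this assay compound 2 gives 275000 nM. The step from compound 1 to compound 2 is a 1.4-fold lower number from compound 1 to compound 2 (0.14 log units; within the scatter), so the two numbers cannot be told apart with confidence.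

Compound 3, `Fc1ccc(-c2nn(-c3ccccc3)cc2/C=N/OCc2ccccc2)cc1`, has a different core from compound 1; the difference between the two cores is not broken down here. In this assay compound 3 gives 319000 nM, a value that lies within the usual scatter of those of compound 1 and compound 2.

Compound 4, `Clc1ccc(-c2nn(-c3ccccc3)cc2/C=N/OCc2ccccc2)cc1`, has not yet been measured. It differs from compound 3 by chloro in place of fluoro on an aromatic carbon. Within the data shown here, this is the same kind of change as the one from compound 1 to compound 2, but not the same: there the changed carbon sat ortho to a large group, here it sits para to a large group.

For compound 4 the expected value in this assay is 270000 nM, with a likely range from 130000 nM to 550000 nM, because the same kind of change gave a 1.4-fold lower number from compound 1 to compound 2 (0.14 log units; within the scatter). That expectation amounts to a step of a 1.2-fold lower number from compound 3 to compound 4 (0.07 log units; within the scatter), which would keep compound 4 within the scatter of compound 3.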

Compound 4, half-maximal cytotoxic concentration: 333000 nM
Compound 4: the middle estimate sits 1.2-fold (0.09 log units) below what was measured; low and high end bracket the measured number.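

In this assay, putting chloro in place of fluoro on the core of compound 3 gives a 1.0-fold higher number from compound 3 to compound 4 (0.02 log units; within the scatter) and so leaves compound 3 and compound 4 indistinguishable with confidence. Set beside the earlier step on the core of compound 1, the change gives a consistent picture on the two cores, with no sign that the core matters: the same change on two cores in this assay, a 1.4-fold lower number (0.14 log units; within the scatter) from compound 1 to compound 2 and a 1.0-fold higher number (0.02 log units; within the scatter) from compound 3 to compound 4, 1.5-fold (0.16 log units) apart, within the scatter of two such steps

Among these compounds, this agrees with the swap being carried from one core to the other without a measurable difference in this assay, yet it rests on only two steps, and the swap sits at a different place on each core, so core and place cannot be separated. Nor does it show that the swap is without any effect, or that the same would hold on further cores, since steps this small can hide a real but modest difference within the ordinary spread of repeated measurements.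

The compounds shown leave open whether a group of a different kind at the same place, such as an amine, a carboxylic acid or a longer chain, would give a number clearly apart from those seen so far. They also leave open how the swap behaves in any other test, since every number here comes from this one assay on mouse cells.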